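Swapping Acetyl for Dimethylamino on a Shared Core

The source may hold more compounds than are shown below. What is called first, only, known or untested is meant among the compounds shown, and "the series" means these compounds.

Compound 1 `COc1cc(C)cc(-c2c(-c3ccnc(-c4ccc(C(C)=O)cc4)c3)cnn2CC#N)c1` and compound 2 `COc1cc(C)cc(-c2nn(CC#N)cc2-c2ccnc(-c3ccc(N(C)C)cc3)c2)c1` were tested in a functional assay on COLO 205 cells (Homo sapiens) for cytotoxicity, read by sulforhodamine B assay, with a stated time of 48 h, tested at 0.001 uM; a lower number here means a stronger effect, a higher number a weaker effect of the compound at the concentration tested. Compound 1 gives 109% and compound 2 gives 107%; the two numbers lie within the scatter of each other, so neither stands apart, and both show essentially no effect at this concentration. Compound 3 `COc1cc(C)cc(-c2c(-c3ccnc(-c4ccc(N(C)C)cc4)c3)cnn2CC#N)c1` is not yet measured. It differs from compound 1 by dimethylamino in place of acetyl on an aromatic carbon. Among the measured compounds shown here, no step between measured compounds is available. Since compound 2, which also carries dimethylamino, gives 107%, compound 3 is expected to give 106% (94% to 118%), and the step of a number 3 percentage points lower from compound 1 to compound 3 (within the scatter) is expected to stay within the scatter.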

Compound 3, a percentage reported as activity, at one concentration (the size of the read-out at that concentration, not a potency): 98%
Compound 3: the middle estimate sits 8 percentage points above what was measured, and the stated range covers the measured number.
By their numbers in this assay, from the lowest: compounds 3, 2 and 1 (each within the scatter of the next, the first and the last beyond it).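

In this assay the change from 4-acetylphenyl to 4-(dimethylamino)phenyl gives a number 11 percentage points lower from compound 1 to compound 3 (beyond the scatter) on the shared core, so the group at this position can shift the read-out even at this very low concentration. The two groups match in heavy-atom count and in hydrogen-bond acceptors, so neither count separates them. No measurement here accounts for the step. Going by these compounds, whether a primary amine or a carboxylic acid at this position would move the number further remains open.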